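Trifluoromethyl in Place of Hydrogen on the Shared Core

The source may report more compounds than this note shows. Statements on the series, on what has been measured and on what is new or still open speak of the compounds shown alone.

Compound 1 `c1cncc(-c2nc3ccccc3n2C2CC2)c1`: > 8330 nM
Compound 2 `Fc1cccc2nc(-c3cccnc3)n(C3CC3)c12`: > 10000 nM
Compound 3 `COc1ccc2nc(-c3cccnc3)n(C3CC3)c2c1`: 1980 nM

In an assay on V79 cells for inhibition of cytochrome P450 11B1, mitochondrial (Homo sapiens), read by HTRF, with a stated time of 1 h (on this read-out lower numbers stand for stronger inhibition and higher numbers for weaker inhibition), compound 1 gives > 8330 nM, a limit of the assay and not a number. Compound 2 likewise gives > 10000 nM, also a limit. Compound 3 gives 1980 nM. Compound 1 therefore stands at a limit, as does one further value of the three; only compound 3 has a readable number.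

The step that the two limits leave unreadable from compound 1 to compound 2 stays unreadable, since both values sit at limits (the limit of > 8330 nM in this assay, at which 1 of the 3 values shown sits, (the limit of > 10000 nM in this assay, at which 1 of the 3 values shown sits)). The step of an at least 4.2-fold lower number from compound 1 to compound 3 (0.62 log units; beyond the scatter) is the only readable one and shows that a group in place of hydrogen on the core of compound 1 can lower the number beyond the scatter.

Compound 4 `FC(F)(F)c1ccc2c(c1)nc(-c1cccnc1)n2C1CC1` differs from compound 1 by trifluoromethyl in place of hydrogen on an aromatic carbon. The step from compound 1 to compound 3 bears on it most directly, though methoxy and trifluoromethyl are different groups, so the size is uncertain. A lowering of the number is expected, estimated as an at least 1.6-fold lower number from compound 1 to compound 4 (0.22 log units; that floor lies within the scatter), with a fair chance that this assay again reports only a limit. Compound 4 is expected to give 5000 nM, in the range 1500 nM to 20000 nM.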

Compound 4, half-maximal inhibitory concentration: > 10000 nM
Compound 4 ended at the assay's limit; the forecaster's own chance of this, stated with the estimate: 40%; middle value at least 2.0-fold (0.30 log units) away from the limit.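

In this assay compound 4 gives > 10000 nM, a limit of the assay and not a number. For the compounds shown here, compound 1 also sits at a limit, so no step from compound 1 to compound 4 can be read. The compounds shown leave open whether trifluoromethyl in place of hydrogen changes the number at all.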